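The compounds below may be only part of what the source reports. "The series", "measured", "known", "first", "only" and "open" are said of these compounds alone.

Measured so far in a functional assay on UACC-257 cells (Homo sapiens) for inhibition; on this read-out lower numbers stand for stronger inhibition of growth and higher numbers for weaker inhibition of growth:
compound 1 `COc1cc(/C=C/C(=O)c2cccc(-n3cc(-c4ccc(Cl)cc4)[nH]c3=O)c2)cc(OC)c1OC` gives 17400 nM
compound 2 `COc1cc(/C=C/C(=O)c2cccc(-n3cc(-c4ccccc4)[nH]c3=O)c2)cc(OC)c1OC` gives 1520 nM
compound 3 `COc1ccc(-c2cn(-c3cccc(C(=O)/C=C/c4ccc(O)c(OC)c4)c3)c(=O)[nH]2)cc1` gives 13300 nM

Compound 3 stands second highest of these three numbers: close to compound 1, within the scatter, and far from compound 2, beyond it. Compound 4 `COc1ccc(-c2cn(-c3cccc(C(=O)/C=C/c4cc(OC)c(OC)c(OC)c4)c3)c(=O)[nH]2)cc1` differs from compound 3 by 3,4,5-trimethoxyphenyl in place of 4-hydroxy-3-methoxyphenyl on a double-bonded chain carbon bound to a double-bonded chain carbon. For the measured compounds named here, the only measured step, an 11-fold lower number from compound 1 to compound 2 (1.06 log units; beyond the scatter), concerns a change on the other ring of the core, not the chain-end group, so no measured step bears directly on this change. Compounds 1 and 2 carry the entering group, but they differ from compound 4 elsewhere too. The direction is therefore expected to be uncertain, with a 1.5-fold lower number from compound 3 to compound 4 (0.17 log units; within the scatter) likely within the scatter. Compound 4 is estimated at 9000 nM, from 2500 nM to 30000 nM.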

Compound 4, concentration for 50% growth inhibition: 3040 nM
Compound 4: middle estimate off by 3.0-fold (0.47 log units), on the high side, and the stated range covers the measured number.
By their numbers in this assay, from the lowest: compounds 2 and 4 (each within the scatter of the next); then compounds 3 and 1 (each within the scatter of the next).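

In this assay, the chain-end group turns out to matter: 3,4,5-trimethoxyphenyl in place of 4-hydroxy-3-methoxyphenyl gives a 4.4-fold lower number from compound 3 to compound 4 (0.64 log units; beyond the scatter). On the other ring, with this chain end, methoxy in place of hydrogen gives a 2.0-fold higher number from compound 2 to compound 4 (0.30 log units; within the scatter), so the two compounds stay within the scatter, while methoxy in place of chloro gives a 5.7-fold lower number from compound 1 to compound 4 (0.76 log units; beyond the scatter), a step beyond it. Nothing measured here offers a reason for these steps. The compounds shown leave open how an amine or a carboxylic acid on the chain-end ring would compare. They also do not separate the loss of the hydroxy group from the gain of methoxy groups.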